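Nitro in place of methoxy: expectation for compound 3

A few compounds are considered here, and "the series" means these few. Any claim that something is new, unique, unknown or untested is made for them only; others in the source may bear on it.

In a functional assay on MCF7 cells (Homo sapiens) for antiproliferative activity, read by CCK-8 assay, with a stated time of 72 h (a higher number here means a weaker inhibitor, a lower number a stronger inhibitor), compound 1 `Cc1cc(Nc2cc(N3CCN(C)CC3)nc(Nc3ccc(Cl)cc3)n2)n[nH]1` gives 840 nM and compound 2 `COc1cccc(Nc2nc(Nc3cc(C)[nH]n3)cc(N3CCN(C)CC3)n2)c1` gives 933 nM. These two numbers lie within the scatter of each other, so compound 2 stands level with compound 1. Compound 3 `Cc1cc(Nc2cc(N3CCN(C)CC3)nc(Nc3cccc([N+](=O)[O-])c3)n2)n[nH]1` carries nitro in place of methoxy on an aromatic carbon, meta to a large group, which reads as 3-methoxyphenyl to 3-nitrophenyl: nitro in place of methoxy on an aromatic carbon. Within the data shown here, no measured compound carries nitro, so the data give no direct reading on this group. Among the measured compounds shown here, the only measured step bearing on the change is a 1.1-fold higher number from compound 1 to compound 2 (0.05 log units; within the scatter), with 3-methoxyphenyl in place of 4-chlorophenyl, and it stays within the scatter. On that single step, no change beyond the scatter is expected in this assay, in either direction. The expected step is a 1.0-fold lower number from compound 2 to compound 3 (0.02 log units; within the scatter). For compound 3 the estimated value is 900 nM, with an expected range of 300 nM to 2500 nM.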

Compound 3, half-maximal inhibitory concentration: 642 nM
Estimate against measurement, compound 3: 1.4-fold (0.15 log units) above; the measured number falls inside the stated range.
By their numbers in this assay, from the lowest: compounds 3, 1 and 2 (each within the scatter of the next).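

In this assay, nitro in place of methoxy on an aromatic carbon, meta to a large group, gives a 1.5-fold lower number from compound 2 to compound 3 (0.16 log units; within the scatter), so this place accepts both groups without a change beyond the scatter. The step with 3-nitrophenyl in place of 4-chlorophenyl gives a 1.3-fold lower number from compound 1 to compound 3 (0.12 log units; within the scatter), which leaves compound 1, compound 2 and compound 3 level with one another, even though that step alters both the group and where it sits on the ring. No measurement on hand accounts for this flat reading.

From the compounds shown here alone, whether an amine or a carboxylic acid on the same aromatic carbon keeps the number level remains open. Also open, going by these compounds, is how 3-chlorophenyl reads, as it would separate the effect of the group from that of its place on the ring.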